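N-methylation of the linker nitrogen in the pyrazolyl-aminopyrimidine series

This account rests on a few compounds, and the source may have more. Where it says the series, first, only, none or still open, it means among the compounds named here.

Compound 1 `C[C@H](Nc1nccc(Nc2cc(C3CC3)[nH]n2)n1)c1ccc2[nH]ccc2n1` gives the lowest of the two numbers in an assay for inhibition of serine/threonine-protein kinase PAK 1 (Homo sapiens), read by FRET and Z'-LYTE, with stated times of 10 min and 60 min (a higher number here means a weaker inhibitor, a lower number a stronger inhibitor), at 32 nM; compound 2 `C[C@H](Nc1nccc(Nc2cc(C3CC(F)(F)C3)[nH]n2)n1)c1ccc2[nH]ccc2n1` gives 68 nM in this assay, a step of a 2.1-fold higher number from compound 1 to compound 2 (0.33 log units; beyond the scatter). Compound 3 `C[C@@H](c1ccc2[nH]ccc2n1)N(C)c1nccc(Nc2cc(C3CC3)[nH]n2)n1` differs from compound 1 by methyl in place of hydrogen on a nitrogen on an aromatic ring. For the measured compounds named here, no measured step touches this nitrogen; the only step known, from compound 1 to compound 2, concerns the ring on the aromatic carbon and does not bear on it. Without a precedent, a weakening step is expected, a 4.7-fold higher number from compound 1 to compound 3 (0.67 log units; beyond the scatter), and compound 3 is estimated at 150 nM with a range from 40 nM to 800 nM.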

Compound 3, inhibition constant: 18 nM
Compound 3: the middle estimate sits 8.3-fold (0.92 log units) above what was measured; the measured number lies below the stated range.
By their numbers in this assay, from the lowest: compounds 3 and 1 (each within the scatter of the next); then compound 2.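

In this assay, methyl in place of hydrogen on a nitrogen on an aromatic ring gives a 1.8-fold lower number from compound 1 to compound 3 (0.25 log units; within the scatter) and so leaves the number within the scatter. For the compounds shown here, this is the first reading at this nitrogen, and it shows that its hydrogen can be replaced by methyl without a step beyond the scatter, at least with cyclopropyl on the aromatic carbon. Nothing at hand offers an explanation for this result. Open, on these data alone, is whether the same methyl is tolerated with 3,3-difluorocyclobutyl on the aromatic carbon. Also open, as far as these compounds go, is whether an ethyl group or a longer chain carrying an amine is accepted on this nitrogen.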